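One measured compound and a sizeable new group

A few compounds are considered here, and "the series" means these few. Any claim that something is new, unique, unknown or untested is made for them only; others in the source may bear on it.

Among the compounds with values here, three compounds sharing one core have gone through a physicochemical assay for lipophilicity, at pH 7.4 (on this read-out higher numbers stand for higher lipophilicity and lower numbers for lower lipophilicity), but only one gave a number. Compound 2 `Cc1n[nH]c(-c2ncc3cccnc3c2O)n1` gives 0.73, the only figure available. Compound 1 `Oc1c(-c2nc(C(O)c3ccccc3)n[nH]2)ncc2cccnc12` gives "not determined" (no result reported), and compound 3 `O=C1CCCN1Cc1n[nH]c(-c2ncc3cccnc3c2O)n1` gives "not determined" (no result reported). Compound 2 therefore cannot be ranked as high or low within this small set; it serves only as a single reference point.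

Compound 4 `Cc1n[nH]c(-c2ncc3c(N4CCCCS4(=O)=O)ccnc3c2O)n1` has yet to be measured. It differs from compound 2 in one place: a group of 8 heavy atoms (4 carbon, 1 nitrogen, 2 oxygen, 1 sulfur; one six-membered non-aromatic ring with 2 hetero atoms) in place of a hydrogen atom, on an aromatic carbon. The new group, which contains one six-membered non-aromatic ring with 2 hetero atoms, sits on an aromatic carbon, opposite the ring nitrogen.

Within the data shown here, no pair of measured compounds shows how a change on this core shifts this assay, so there is no measured step to borrow. What remains is the reference value, with compound 2 at 0.73, and the makeup of the new group, which has carbon alongside nitrogen, oxygen and sulfur. A modest rise is expected, a number 0.27 log units higher from compound 2 to compound 4 (within the scatter), and it may stay within the usual scatter. The estimated value for compound 4 is 1, with an expected range of 0.4 to 1.6.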

Compound 4, distribution coefficient: 1.5
For compound 4 the middle estimate is 0.50 log units below the measured one; the range from low to high includes it.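

In this assay, within the data shown here, this is the first reading of what a change on the shared core does: putting the six-membered non-aromatic ring with 2 hetero atoms in place of a hydrogen atom, on the aromatic carbon opposite the ring nitrogen, gives a number 0.77 log units higher from compound 2 to compound 4 (beyond the scatter). This step is larger than the usual scatter of repeat measurements. Although the new group holds nitrogen, oxygen and sulfur alongside its carbon, on this single step the number goes up at this position, not down. The data shown offer no measurement that accounts for the direction or the size of this step.

As far as these compounds go, it stays open whether a simple amine, a methoxy group or an open chain on the same aromatic carbon would shift the number as far as this ring does, so one step cannot be stretched into a rule for the position. Compound 1 gives "not determined" (no result reported) and compound 3 gives "not determined" (no result reported), so any steps involving these two cannot be read, and the groups they carry add nothing yet to the picture in this assay.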